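Removing the aromatic fluoro from compound 2

A few compounds are considered here, and "the series" means these few. Any claim that something is new, unique, unknown or untested is made for them only; others in the source may bear on it.

Compound 1, with the structure `Cc1cc(S(=O)(=O)N2CCC[C@@H]2c2ccc(F)cc2)cc(C)c1F`, is the parent of this small set. In an assay on isolated protein for inhibition of transient receptor potential cation channel subfamily A member 1 (Homo sapiens) (a lower number here means a stronger inhibitor, a higher number a weaker inhibitor), compound 1 gives 110 nM. Compound 2, with the structure `Cc1cc(S(=O)(=O)N2[C@H](CO)CC[C@@H]2c2ccc(F)cc2)cc(C)c1F`, carries a hydroxymethyl on the saturated ring, and in this assay compound 2 gives 63 nM, the lowest of the two numbers given here; the step of a 1.7-fold lower number from compound 1 to compound 2 (0.24 log units; within the scatter) stays within the usual scatter. Compound 3, with the structure `Cc1cc(S(=O)(=O)N2[C@H](CN(C)C)CC[C@@H]2c2ccc(F)cc2)cc(C)c1F`, carries a (dimethylamino)methyl instead. For compound 3 this assay reports only a limit, > 18000 nM, as stated in the limit of > 18000 nM in this assay, at which 1 of the 3 values shown sits. The steps of an at least 160-fold higher number from compound 1 to compound 3 (2.21 log units; beyond the scatter) and an at least 280-fold higher number from compound 2 to compound 3 (2.45 log units; beyond the scatter) are therefore large, both beyond the scatter.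

Compound 4, with the structure `Cc1cc(C)cc(S(=O)(=O)N2[C@H](CO)CC[C@@H]2c2ccc(F)cc2)c1`, differs from compound 2 only on the aromatic ring: hydrogen in place of fluoro on an aromatic carbon. None of the three measured steps touches that ring; all of them concern the group on the saturated ring carbon. So the measured steps give no guide to this change, and the expectation is that compound 4 stays close to compound 2, with a step of a 1.4-fold higher number from compound 2 to compound 4 (0.15 log units; within the scatter) that is expected to lie within the scatter. On that basis compound 4 is estimated at 90 nM in this assay, with a range from 30 nM to 280 nM.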

Compound 4, half-maximal inhibitory concentration in the transient receptor potential cation channel subfamily A member 1 assay: 290 nM
Compound 4: middle estimate off by 3.2-fold (0.51 log units), on the low side; the whole stated range lies below it.
By their numbers in the transient receptor potential cation channel subfamily A member 1 assay, from the lowest: compounds 2 and 1 (each within the scatter of the next); then compound 4. At a limit, above all of these: compound 3.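

In the transient receptor potential cation channel subfamily A member 1 assay compound 4 gives 290 nM, so the aromatic ring of this series is not a silent part of the molecule. In the transient receptor potential cation channel subfamily A member 1 assay, hydrogen in place of fluoro on an aromatic carbon, ortho to two methyl groups and para to a large group, gives a 4.6-fold higher number from compound 2 to compound 4 (0.66 log units; beyond the scatter), a modest step, although only one heavy atom leaves and the group on the saturated ring stays as it is. Among these compounds, all the earlier steps concerned that saturated ring carbon, so they could say nothing about this position, and this result shows that a single fluoro here can separate two compounds by more than the scatter. In a physicochemical assay for lipophilicity, at pH 7.4 (on this read-out lower numbers stand for lower lipophilicity and higher numbers for higher lipophilicity), compound 2 gives 3.3 and compound 4 gives 3.2. In the physicochemical assay the same change gives a number 0.10 log units lower from compound 2 to compound 4 (within the scatter), and none of the information shown accounts for the change in inhibition.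

On these data alone, whether a chloro or a methoxy on this aromatic carbon would keep the number of compound 2 or lose ground as compound 4 does remains open. Also open, as far as these compounds go, is whether the same swap of fluoro for hydrogen has a step of similar size in compound 1, which lacks the hydroxymethyl.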